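The source may report more compounds than this note shows. Statements on the series, on what has been measured and on what is new or still open speak of the compounds shown alone.

The study follows one small change at the far end of the molecule and asks what it does to cytotoxicity in an ADME assay on MT4 cells (Homo sapiens) for cytotoxicity, read by MTT assay; on this read-out lower numbers stand for higher toxicity in this test and higher numbers for lower toxicity in this test. Compound 1 `O=C(CSc1nc(Cc2c(Cl)cccc2Cl)cc(=O)[nH]1)c1ccc(F)cc1` is the starting point. In this assay compound 1 gives > 59000 nM, which is a limit of the assay and not a number. Compound 2 `COc1ccc(C(=O)CSc2nc(Cc3c(Cl)cccc3Cl)cc(=O)[nH]2)cc1` differs from compound 1 by methoxy in place of fluoro on an aromatic carbon. In this assay compound 2 gives > 11000 nM, again only a limit of the assay. The step that the two limits leave unreadable from compound 1 to compound 2 is therefore not readable, because compound 1 sits at the limit of > 59000 nM in this assay, at which 1 of the 3 values shown sits, and compound 2 sits at the limit of > 11000 nM in this assay, at which 1 of the 3 values shown sits.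

Compound 3 `CCc1c(Cc2c(F)cccc2Cl)nc(SCC(=O)c2ccc(F)cc2)[nH]c1=O` has a core that differs from the core of compound 1 in more than one place; the difference between the two cores is not broken down here. In this assay compound 3 gives > 57000 nM, once more a limit of the assay, at the limit of > 57000 nM in this assay, at which 1 of the 3 values shown sits. Compound 4 `CCc1c(Cc2c(F)cccc2Cl)nc(SCC(=O)c2ccc(OC)cc2)[nH]c1=O`, not yet measured, stands to compound 3 as compound 2 stands to compound 1: methoxy in place of fluoro on an aromatic carbon, the same change at the same place, para to a large group on a six-membered aromatic ring of carbon only.

The expected step is an at least 1.1-fold lower number from compound 3 to compound 4 (0.05 log units; that floor lies within the scatter), essentially no change, and this expectation rests on a step that the two limits leave unreadable from compound 1 to compound 2, where the same change left both ends at limits. Compound 4 is expected to give about 50000 nM, between 15000 nM and 150000 nM, and most probably the assay will again report only a limit.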

Compound 4, half-maximal cytotoxic concentration: > 11000 nM
Compound 4: only a limit was reported (the forecaster's own chance of this, stated with the estimate: 85%); the middle value does not contradict the limit.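

In this assay compound 4 gives > 11000 nM, again a limit of the assay and not a number. Compound 3 gives > 57000 nM, also a limit, so no step can be read from compound 3 to compound 4. The compounds shown leave open how large any of these four values really is, and whether methoxy in place of fluoro changes the read-out at all.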